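Working notes: adding chloro to compound 2

This account rests on a few compounds, and the source may have more. Where it says the series, first, only, none or still open, it means among the compounds named here.

Measured in a functional assay on A549 cells (Homo sapiens) for antiproliferative activity, read by MTT assay, with a stated time of 48 h; on this read-out lower numbers stand for stronger inhibition and higher numbers for weaker inhibition:
- compound 1 `CCn1c(N)c(-c2nc3ccccc3[nH]2)c2nc(C#N)c(C#N)nc21` > 50000 nM (a limit of the assay)
- compound 2 `CN(C)CCCn1c(N)c(-c2nc3ccccc3[nH]2)c2nc(C#N)c(C#N)nc21` 10400 nM

Compound 1 sits at a limit of the assay, (the limit of > 50000 nM in this assay, at which 1 of the 2 values shown sits). In this assay, among the compounds with values here, compound 2 gives the only actual number so far, 10400 nM, so it has no measured neighbour to be ranked against.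

The next compound is compound 3 `CN(C)CCCn1c(N)c(-c2nc3cc(Cl)ccc3[nH]2)c2nc(C#N)c(C#N)nc21`, which differs from compound 2 by chloro in place of hydrogen on an aromatic carbon. In words, this is chloro in place of hydrogen on an aromatic carbon, turning 1H-benzimidazol-2-yl into 5-chloro-1H-benzimidazol-2-yl.

Within the data shown here, the one measured step is an at least 4.8-fold lower number from compound 1 to compound 2 (0.68 log units; beyond the scatter). That step lies on the saturated chain, not on the aromatic carbon changed here, and it is bounded by a limit, so it sets no size for the new change. Among the measured compounds shown here, with no measured step at this place, the expectation starts from compound 2 at 10400 nM, and no shift beyond the scatter is assumed.

The estimated step is a 1.3-fold lower number from compound 2 to compound 3 (0.11 log units; within the scatter). For compound 3 the expected value is 8000 nM, with an estimated range of 3000 nM to 20000 nM.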

Compound 3, half-maximal inhibitory concentration: > 50000 nM
Compound 3: only a limit was reported; the forecaster's own chance of this, stated with the estimate: 5%; middle value at least 6.2-fold (0.79 log units) from the limit.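

In this assay, within the data shown here, chloro in place of hydrogen on this aromatic carbon gives an at least 4.8-fold higher number from compound 2 to compound 3 (0.68 log units; beyond the scatter), the first measured change at this place and one that goes beyond the scatter. Compound 3 gives > 50000 nM, which is a limit of the assay, so the step has a lower bound and no exact size. The dimethylamino chain is shared by compound 2 and compound 3, so its presence alone does not secure a numerical reading once chloro stands on this carbon, and the series now rests on a single actual number: the limit of > 50000 nM in this assay, at which 2 of the 3 values shown sit.

On these data alone, it remains open whether the change in read-out is tied to chloro itself or would also follow from another group on the same carbon, such as fluoro, methoxy or an amine, any of which could be set against compound 2 at 10400 nM. As far as these compounds go, it is also open whether chloro at this place would give a numerical reading alongside a longer chain or a cyclic amine in place of the dimethylamino group.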